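Replacing a Chlorine Atom on a Purine-Type Core

This account rests on a few compounds, and the source may have more. Where it says the series, first, only, none or still open, it means among the compounds named here.

The study concerns inhibition of a cell-cycle kinase, measured in an assay on isolated protein (Asteroidea) for inhibition of G2/mitotic-specific cyclin-B (Asterina pectinifera), read by scintillation counting and 33P incorporation, with a stated time of 30 min; a higher number here means a weaker inhibitor, a lower number a stronger inhibitor. Among the measured compounds shown here, compound 1 (`CC(C)n1cnc2c(Nc3cccc(-c4ncccn4)c3)nc(Cl)nc21`) is the only compound with a number: in this assay compound 1 gives 10000 nM, a weak result. Two related compounds come without a number. Compound 2 (`CC(C)n1cnc2c(Nc3cccc(-c4cncnc4)c3)nc(Cl)nc21`) is recorded in this assay as "not determined" (no result reported), and compound 3 (`CC(C)CC[C@H](O)Nc1nc(Nc2ccc(-c3cncnc3)cc2)c2ncn(C(C)C)c2n1`) likewise as "not determined" (no result reported), so neither helps to gauge a step.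

Compound 4 (`CCC[C@@H](O)Nc1nc(Nc2cccc(-c3ncccn3)c2)c2ncn(C(C)C)c2n1`) differs from compound 1 in one place: a group of 6 heavy atoms (4 carbon, 1 nitrogen, 1 oxygen; no ring) in place of one chlorine atom, on an aromatic carbon — a group of 6 heavy atoms (4 carbon, 1 nitrogen, 1 oxygen; no ring) in place of one chlorine atom, on an aromatic carbon, between two ring nitrogen atoms of the shared core.

For the measured compounds named here, no measured pair shows this exact step, so any expectation rests only on the weak value of compound 1 and on the size of the change. Compound 4 is expected to be a considerably stronger inhibitor, with a step from compound 1 of a 67-fold lower number from compound 1 to compound 4 (1.82 log units; beyond the scatter), well beyond the scatter. The estimate for compound 4 is 150 nM, with a range from 15 nM to 1500 nM.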

Compound 4, half-maximal inhibitory concentration: 300 nM
Compound 4: middle estimate off by 2.0-fold (0.30 log units), on the low side; the range from low to high includes it.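

In this assay, the aromatic carbon between two ring nitrogen atoms proves to be a position where a change can move the result a long way: replacing the chloro group with the open-chain group of 6 heavy atoms gives a 33-fold lower number from compound 1 to compound 4 (1.52 log units; beyond the scatter) as a large step. Before this, a single number offered no step, so nothing showed whether this position mattered. The chlorine atom can evidently give way to a much larger group with a defined stereocentre, and the inhibitor becomes stronger rather than weaker, but no measurement shown here explains why. 

One replacement cannot show which part of the new group accounts for the gain. A simple amine, a longer chain or the opposite arrangement at the stereocentre could each behave differently at this position, and the compounds shown do not settle this.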